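Benzyl to 2-hydroxyethyl on the shared core

The compounds below may be only part of what the source reports. "The series", "measured", "known", "first", "only" and "open" are said of these compounds alone.

Values in a functional assay on U-937 cells (Homo sapiens) for cytotoxicity, read by MTT assay, with a stated time of 24 h; on this read-out higher numbers stand for weaker inhibition and lower numbers for stronger inhibition:
Compound 1 `OCCCOc1c(Br)cc(Br)cc1Oc1ccc(Br)cc1Br`: 32.3 ug/mL
Compound 2 `CCOC(=O)C(C)Oc1c(Br)cc(Br)cc1Oc1ccc(Br)cc1Br`: 39.5 ug/mL
Compound 3 `Brc1ccc(Oc2cc(Br)cc(Br)c2OCc2ccccc2)c(Br)c1`: 29 ug/mL

Compound 3 (29 ug/mL) holds no separate rank, since all three numbers lie within the scatter of one another. The next compound is compound 4 `OCCOc1c(Br)cc(Br)cc1Oc1ccc(Br)cc1Br`, which has hydroxymethyl in place of phenyl on a saturated chain carbon bound to an oxygen on an aromatic ring. The same difference reads benzyl to 2-hydroxyethyl.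

The most relevant measurement is a 1.1-fold lower number from compound 1 to compound 3 (0.05 log units; within the scatter), since it links the benzyl group to a 3-hydroxypropyl chain, the measured group nearest to 2-hydroxyethyl. The ester-bearing group adds two further steps, a 1.2-fold higher number from compound 1 to compound 2 (0.09 log units; within the scatter) and a 1.4-fold lower number from compound 2 to compound 3 (0.13 log units; within the scatter). None of these three compounds departs from the others beyond the scatter, so no step beyond it is expected here in this assay. The expected change is a 1.1-fold higher number from compound 3 to compound 4 (0.04 log units; within the scatter), with no firm direction. The estimate for compound 4 is 32 ug/mL, with an expected range from 20 ug/mL to 50 ug/mL.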

Compound 4, half-maximal inhibitory concentration: 34.5 ug/mL
The estimate for compound 4 lay 1.1-fold (0.03 log units) below the measured number; measured number inside the range.
By their numbers in this assay, from the lowest: compounds 3, 1, 4 and 2 (each within the scatter of the next).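

In this assay, exchanging benzyl for 2-hydroxyethyl swaps a six-membered aromatic ring for a hydroxymethyl end with one hydrogen-bond donor, and the step stays within the scatter (a 1.2-fold higher number from compound 3 to compound 4 (0.08 log units; within the scatter)). The 2-hydroxyethyl group also reads alike with 3-hydroxypropyl (a 1.1-fold higher number from compound 1 to compound 4 (0.03 log units; within the scatter)) and with 1-(ethoxycarbonyl)ethyl (a 1.1-fold lower number from compound 2 to compound 4 (0.06 log units; within the scatter)). With compound 4 in place, a phenyl ring, a hydroxy end at either of two chain lengths and an ester all lie within the scatter of one another on this oxygen on an aromatic ring, so none of these groups separates from the others in this assay.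

Going by these compounds, whether a primary amine or a carboxylic acid at the end of this chain, or a much longer chain, would leave the read-out as flat remains open. No measurement at hand offers an explanation for this flat picture.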